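This account rests on a few compounds, and the source may have more. Where it says the series, first, only, none or still open, it means among the compounds named here.

Compound 3 `COc1cc(-c2ccnc3cc(-c4cccc(C#N)c4)nn23)cc(OC)c1OC` is one of three compounds with a result in a functional assay on B16-F0 cells (Mus musculus) for inhibition, read by CCK-8 assay, with a stated time of 48 h; a lower number here means a stronger inhibitor, a higher number a weaker inhibitor. In this assay compound 3 reaches only a limit, > 10000 nM, so its true number is not known (the limit of > 10000 nM in this assay, at which 1 of the 3 values shown sits). Compound 1 `COc1cc(-c2ccnc3cc(-c4ccc5cnn(C)c5c4)nn23)cc(OC)c1OC` gives 1000 nM, and compound 2 `COc1cc(-c2ccnc3cc(-c4ccc(C)c(C)c4)nn23)cc(OC)c1OC` gives 391 nM. The change to compound 4 `COc1cc(-c2ccnc3cc(-c4cccc(C)c4)nn23)cc(OC)c1OC` is methyl in place of cyano on an aromatic carbon. Among the measured compounds shown here, two measured steps bear on it: an at least 25-fold higher number from compound 2 to compound 3 (1.40 log units; beyond the scatter) and an at least 10-fold higher number from compound 1 to compound 3 (1.00 log units; beyond the scatter), both pointing to the cyano as the feature that accompanies the weakest inhibition. Taking the cyano away in favour of methyl should therefore move the number strongly the other way, and compound 4 is expected to shift by an at least 12-fold lower number from compound 3 to compound 4 (1.09 log units; beyond the scatter). The estimate for compound 4 is 800 nM, in the range 300 nM to 3000 nM.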

Compound 4, half-maximal inhibitory concentration: 2220 nM
The estimate for compound 4 lay 2.8-fold (0.44 log units) below the measured number; low and high end bracket the measured number.
By their numbers in this assay, from the lowest: compound 2; then compound 1; then compound 4. At a limit, above all of these: compound 3.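

Methyl in place of cyano on this aromatic carbon gives an at least 4.5-fold lower number from compound 3 to compound 4 (0.65 log units; beyond the scatter) in this assay, so a measurable number returns. Going by these compounds, compound 3 stands only at a limit, so the true size of this step is unknown: the limit of > 10000 nM in this assay, at which 1 of the 4 values shown sits. A single methyl does not match the 3,4-dimethylphenyl group, as hydrogen in place of its other methyl gives a 5.7-fold higher number from compound 2 to compound 4 (0.75 log units; beyond the scatter), and 3-methylphenyl in place of 1-methyl-1H-indazol-6-yl gives a 2.2-fold higher number from compound 1 to compound 4 (0.35 log units; beyond the scatter).

The compounds shown leave open how a methoxy, an amine or a carboxylic acid at this place would compare.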